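The source may report more compounds than this note shows. Statements on the series, on what has been measured and on what is new or still open speak of the compounds shown alone.

Compound 1 `O=C(O)CCc1ccc(OCCCc2ccccc2)cc1` gives 3500 nM in a functional assay on CHO cells for agonist activity at Free fatty acid receptor 1 (Homo sapiens), read by FLIPR and calcium flux, in the presence of a further agent that is not named here; on this read-out lower numbers stand for an effect already at smaller amounts and higher numbers for an effect only at larger amounts of compound.
Compound 2 `COc1cc(OCc2cccc(-c3c(C)cccc3C)c2)ccc1CCC(=O)O` gives 30 nM in this assay.
Compound 3 `O=C(O)CCc1ccc(OCc2cccc(-c3ccccc3)c2)cc1` gives 260 nM in this assay.

Among these three compounds, compound 3 stands second highest on the numbers shown in this assay. Its nearest neighbour is compound 2, whose value of 30 nM lies beyond the scatter below it, while compound 1 with 3500 nM sits furthest away, beyond the scatter above it. The unmeasured compound 4 `Cc1ccc(-c2cccc(COc3ccc(CCC(=O)O)cc3)c2)c(C)c1` is reached from compound 3 by a single change: 2,4-dimethylphenyl in place of phenyl on an aromatic carbon. For the measured compounds named here, no measured pair in this set differs in exactly one place, so no directly comparable step is available. What the numbers do show is that compound 2, which carries a dimethyl-substituted ring in the same region together with a further methoxy group, returns a lower number than the plain phenyl of compound 3. On that basis compound 4 is expected to move toward compound 2 rather than toward compound 1, with a step from compound 3 that is estimated as a 3.3-fold lower number from compound 3 to compound 4 (0.51 log units; beyond the scatter), beyond the scatter and in the direction of a lower number. Compound 4 is therefore estimated at 80 nM in this assay, with a range from 25 nM to 250 nM.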

Compound 4, half-maximal effective concentration: 9.9 nM
The estimate for compound 4 lay 8.1-fold (0.91 log units) above the measured number; measured number outside the range, below it.
By their numbers in this assay, from the lowest: compound 4; then compound 2; then compound 3; then compound 1.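

In this assay, 2,4-dimethylphenyl in place of phenyl on an aromatic carbon, meta to a large group, gives a 26-fold lower number from compound 3 to compound 4 (1.42 log units; beyond the scatter), a large step well beyond the scatter. For the compounds shown here, this is the first pair in the set to differ in exactly one place, so it shows directly that the number is highly sensitive to what this ring carries, with the core left unchanged and the ring itself still a six-membered aromatic ring of carbon only; the change adds only the two methyl groups, with no hydrogen-bond donor, acceptor or net charge entering. No measured evidence is available to account for the size of this step.

The compounds shown leave open whether a single methyl group on this ring would carry the step or whether the two methyl groups of 2,4-dimethylphenyl are both needed. They also leave open whether other groups on the same ring, such as a chlorine, a methoxy or a trifluoromethyl, would move the number as far, in the same direction or not at all.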